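Methoxyphenyl for Difluorophenyl on a Weak Antiproliferative Lactone

The source may report more compounds than this note shows. Statements on the series, on what has been measured and on what is new or still open speak of the compounds shown alone.

Compound 1 `O=C1O[C@H]([C@@H](O)Cn2cc(-c3cc(F)cc(F)c3)nn2)C(OCc2ccccc2)=C1OCc1ccccc1`: 41200 nM
Compound 2 `O=C1O/C(=C\Cn2cc(-c3ccc(Br)cc3)nn2)C(OCc2ccccc2)=C1OCc1ccccc1`: > 100000 nM

Among the measured compounds shown here, in a functional assay on A549 cells (Homo sapiens) for antiproliferative activity, read by MTT assay, with a stated time of 72 h (on this read-out lower numbers stand for stronger inhibition and higher numbers for weaker inhibition), compound 1 gives 41200 nM, the only full number among the two values shown. Compound 2 reaches only a limit in this assay, > 100000 nM. That value is the limit of > 100000 nM in this assay, at which 1 of the 2 values shown sits.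

Compound 3 `COc1ccccc1-c1cn(C[C@H](O)[C@H]2OC(=O)C(OCc3ccccc3)=C2OCc2ccccc2)nn1` differs from compound 1 by 2-methoxyphenyl in place of 3,5-difluorophenyl on an aromatic carbon. No step between two measured compounds is shown for such a change, so the step of a 1.0-fold lower number from compound 1 to compound 3 (0.01 log units; within the scatter) is expected to stay within the scatter, with no clear direction. Compound 3 is therefore estimated at about 40000 nM, between 12000 nM and 100000 nM.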

Compound 3, half-maximal inhibitory concentration: > 100000 nM
Compound 3: only a limit was reported (the forecaster's own chance of this, stated with the estimate: 25%); at least 2.5-fold (0.39 log units) between middle value and limit.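

The swap from 3,5-difluorophenyl to 2-methoxyphenyl on this aromatic carbon of the five-membered aromatic ring is not neutral, giving an at least 2.4-fold higher number from compound 1 to compound 3 (0.38 log units; beyond the scatter) in this assay. The group at this position therefore affects the antiproliferative read-out, even though compound 1 is already weak. Going by these compounds, the value of compound 3 is only a limit, so the full size of the step stays unknown: the limit of > 100000 nM in this assay, at which 2 of the 3 values shown sit.

The compounds shown do not separate the effect of the methoxy group from that of the two fluorines. They also leave open whether an amine or a carboxylic acid on this phenyl ring would give a lower number than compound 1.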